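The source may hold more compounds than are shown below. What is called first, only, known or untested is meant among the compounds shown, and "the series" means these compounds.

In a functional assay on SK-MEL-2 cells (Homo sapiens) for inhibition, read by sulforhodamine B assay, with a stated time of 48 h, tested at 1 uM (a lower number here means a stronger effect, a higher number a weaker effect of the compound at the concentration tested), compound 3 `COc1cc(Cl)cc(-c2nn(-c3cccc(NC(=O)Nc4ccc(Cl)c(Cl)c4)c3)cc2-c2ccncc2)c1` gives 80%, the second highest of the three numbers recorded. Compound 1 `COc1cc(Cl)cc(-c2nn(-c3cccc(NC(=O)Nc4ccc(Cl)c(C(F)(F)F)c4)c3)cc2-c2ccncc2)c1` gives 84% in this assay, and compound 2 `COc1cc(Cl)cc(-c2nn(-c3cccc(NC(=O)Nc4cc(C(F)(F)F)cc(C(F)(F)F)c4)c3)cc2-c2ccncc2)c1` gives 40% in this assay, a number well below that of compound 3 and beyond the scatter. Compound 4 `COc1cc(Cl)cc(-c2nn(-c3cccc(NC(=O)Nc4cccc(C(F)(F)F)c4)c3)cc2-c2ccncc2)c1` has not yet been measured; it differs from compound 3 by 3-(trifluoromethyl)phenyl in place of 3,4-dichlorophenyl on an amide-type nitrogen. Among the compounds with values here, the one measured step that bears on this change is a number 4 percentage points lower from compound 1 to compound 3 (within the scatter), which lay within the scatter. Compound 4 is therefore expected to show a number 2 percentage points higher from compound 3 to compound 4 (within the scatter), no step beyond the scatter. The estimate for compound 4 in this assay is 82%, within a range from 65% to 96%.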

Compound 4, a percentage reported as activity, at one concentration (the size of the read-out at that concentration, not a potency): 85%
For compound 4 the middle estimate is 3 percentage points below the measured one; measured number inside the range.
By their numbers in this assay, from the lowest: compound 2; then compounds 3, 1 and 4 (each within the scatter of the next).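

In this assay 3-(trifluoromethyl)phenyl in place of 3,4-dichlorophenyl on the amide-type nitrogen gives a number 5 percentage points higher from compound 3 to compound 4 (within the scatter) and hydrogen in place of chloro gives a number 1 percentage points higher from compound 1 to compound 4 (within the scatter) so these groups read alike here. Hydrogen in place of the second trifluoromethyl of compound 2 gives a number 45 percentage points higher from compound 2 to compound 4 (beyond the scatter) and this is the one large step on this ring. No measurement is available that would explain this step. The compounds shown leave open whether a nitrile or an amine on that aromatic carbon would give a number as low as that of compound 2.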